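The source may hold more compounds than are shown below. What is called first, only, known or untested is meant among the compounds shown, and "the series" means these compounds.

Measured in a functional assay on HeLa cells (Homo sapiens) for antiproliferative activity, read by MTT assay, with a stated time of 48 h; on this read-out lower numbers stand for stronger inhibition and higher numbers for weaker inhibition:
- compound 1 `CN(C)CCn1c(N)c(-c2nc3ccccc3[nH]2)c2nc(C#N)c(C#N)nc21`: 8880 nM
- compound 2 `CN1CCN(CCn2c(N)c(-c3nc4ccccc4[nH]3)c3nc(C#N)c(C#N)nc32)CC1`: > 50000 nM (a limit, not a number)
- compound 3 `CCCn1c(N)c(-c2nc3ccccc3[nH]2)c2nc(C#N)c(C#N)nc21`: > 50000 nM (a limit, not a number)

Compound 1 is the only one of the three with a true number, at 8880 nM. The other two sit at the limit of > 50000 nM in this assay, at which 2 of the 3 values shown sit.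

Compound 4 `N#Cc1nc2c(-c3nc4ccccc4[nH]3)c(N)n(CCO)c2nc1C#N` keeps the shared core and changes one group: hydroxy in place of dimethylamino on a saturated chain carbon, two bonds along the chain from an aromatic nitrogen. Hydroxy takes the place of dimethylamino on a saturated chain carbon, two bonds along the chain from an aromatic nitrogen.

Two measured steps replace the same dimethylamino group at the same place. They are an at least 5.6-fold higher number from compound 1 to compound 2 (0.75 log units; beyond the scatter) and an at least 5.6-fold higher number from compound 1 to compound 3 (0.75 log units; beyond the scatter). On these data alone, both point to a higher number, and because each ends at a limit, their true size stays open. Neither replacement is hydroxy, so they guide the direction more firmly than the size.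

A modest rise is therefore expected, an estimated 3.4-fold higher number from compound 1 to compound 4 (0.53 log units; beyond the scatter). The expected value for compound 4 is 30000 nM, with an estimated range from 9000 nM to 70000 nM.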

Compound 4, half-maximal inhibitory concentration: > 50000 nM
Compound 4: no number, only a limit; the forecaster's own chance of this, stated with the estimate: 45%; at least 1.6-fold (0.22 log units) between middle value and limit.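

In this assay, putting hydroxy in place of dimethylamino on the saturated chain carbon gives an at least 5.6-fold higher number from compound 1 to compound 4 (0.75 log units; beyond the scatter); compound 4 has only a limit, not a true number. This third replacement at the position adds a hydroxy group, which has a hydrogen-bond donor, yet it also fails to give a number, so among the four compounds shown only dimethylamino does, and no compound here goes against that. The steps among compounds 2, 3 and 4 cannot be read, so these compounds cannot be ranked against one another: the limit of > 50000 nM in this assay, at which 3 of the 4 values shown sit.

On these data alone, it remains open whether another small amine, such as diethylamino or pyrrolidin-1-yl, would also give a true number at this position. As far as these compounds go, it is equally open whether dimethylamino on a longer chain would do so.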